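Swapping the aniline on compound 3's core

The compounds below may be only part of what the source reports. "The series", "measured", "known", "first", "only" and "open" are said of these compounds alone.

Three cinnamamide-bearing compounds have been measured in a functional assay on PC-3 cells (Homo sapiens) for antiproliferative activity, read by MTT assay, with a stated time of 48 h; on this read-out higher numbers stand for weaker inhibition and lower numbers for stronger inhibition. Compound 1 `O=C(/C=C/c1ccccc1)Nc1cc2ncnc(Nc3ccc(F)c(Cl)c3)c2s1` gives 200 nM, compound 2 `C#Cc1cccc(Nc2ncnc3cc(NC(=O)/C=C/c4ccccc4)sc23)c1` gives 700 nM, and compound 3 `C#Cc1cccc(Nc2ncnc3sc(NC(=O)/C=C/c4ccccc4)cc23)c1` gives 400 nM. Compound 3 thus stands second highest of the three numbers; its nearest neighbour is compound 2, and its furthest is compound 1, both within the scatter of this assay. Compound 4 `O=C(/C=C/c1ccccc1)Nc1cc2c(Nc3ccc(F)c(Cl)c3)ncnc2s1` has not yet been measured; it keeps the core of compound 3 and carries 3-chloro-4-fluorophenyl in place of 3-ethynylphenyl on a nitrogen on an aromatic ring. Among the measured compounds shown here, the one measured step that bears on this change is the same exchange run the other way on the core of compound 1, where the number rose a 3.5-fold higher number from compound 1 to compound 2 (0.54 log units; beyond the scatter). On that basis the step is expected to reverse: a lower number in this assay for compound 4 than for compound 3, of a size estimated at a 2.7-fold lower number from compound 3 to compound 4 (0.43 log units; beyond the scatter). Compound 4 is therefore expected to give about 150 nM in this assay, with a range from 70 nM to 350 nM.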

Compound 4, half-maximal inhibitory concentration: 700 nM
For compound 4 the middle estimate is 4.7-fold (0.67 log units) below the measured one; the whole stated range lies below it.
By their numbers in this assay, from the lowest: compounds 1, 3, 2 and 4 (each within the scatter of the next, the first and the last beyond it).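

Putting 3-chloro-4-fluorophenyl in place of 3-ethynylphenyl on the core of compound 3 gives a 1.8-fold higher number from compound 3 to compound 4 (0.24 log units; within the scatter), so on this core the exchange produces no separation beyond the scatter. The clear separation seen on the core of compound 1 therefore does not carry over to this core. What this exchange does on a nitrogen on an aromatic ring depends on the core that carries it, and a step read on one core cannot stand in for the other: the same change on two cores in this assay, a 3.5-fold higher number (0.54 log units; beyond the scatter) from compound 1 to compound 2 and a 1.8-fold lower number (0.24 log units; within the scatter) from compound 4 to compound 3, 6.1-fold (0.79 log units) apart, beyond the scatter of two such steps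

The compounds leave open what lies behind this difference between the cores, and whether another group on that nitrogen, such as 3-methoxyphenyl or 3-bromophenyl, would also separate them. They also leave open whether the difference would persist with a propanamide in place of the cinnamamide.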